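The source may hold more compounds than are shown below. What is called first, only, known or untested is meant among the compounds shown, and "the series" means these compounds.

Working notes on the series, read in an ADME assay on J774 cells (Mus musculus) for cytotoxicity; a higher number here means that more compound is needed for the effect, a lower number that less compound is needed. Compound 2 `CCc1c(C)[nH]c2cc(OC)c(Cl)cc2c1=O` gives 19000 nM and compound 3 `COc1cc2[nH]c(C)c(C(C)C)c(=O)c2cc1Cl` gives 21700 nM, two values within the scatter of each other. Compound 1 `Cc1[nH]c2ccccc2c(=O)c1/C=C/c1cccc([N+](=O)[O-])c1` stands at > 32600 nM, which is a limit and not a number.

Compound 4 `CCCCC/C=C/c1c(C)[nH]c2cc(OC)c(Cl)cc2c1=O` keeps the core of compound 3 and carries hept-1-en-1-yl in place of isopropyl on an aromatic carbon. Among the compounds with values here, only one measured step bears on this: a 1.1-fold higher number from compound 2 to compound 3 (0.06 log units; within the scatter), with methyl in place of hydrogen on a saturated chain carbon. That step concerns only a small extension of the chain, so it guides the swap to hept-1-en-1-yl only loosely. No shift beyond the scatter is therefore expected in this assay, and no direction can be assigned with confidence. The expected change is a 1.2-fold lower number from compound 3 to compound 4 (0.08 log units; within the scatter). For compound 4 the estimated value is 18000 nM, with an expected range of 7000 nM to 32000 nM.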

Compound 4, half-maximal effective concentration: > 31200 nM
Compound 4: no number, only a limit; the forecaster's own chance of this, stated with the estimate: 30%; at least 1.7-fold (0.23 log units) between middle value and limit.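

In this assay compound 4 gives only a limit and no number: the limit of > 31200 nM in this assay, at which 1 of the 4 values shown sits.

Read against that limit, the swap gives an at least 1.4-fold higher number from compound 3 to compound 4 (0.15 log units; that floor lies within the scatter), and the change from ethyl gives an at least 1.6-fold higher number from compound 2 to compound 4 (0.21 log units; that floor lies within the scatter). Within the data shown here, both floors lie within the scatter, so neither step alone establishes a real rise, but this position on the aromatic carbon, ortho to a methyl group, now shows that the much longer hept-1-en-1-yl brings no drop in the number, whereas the earlier compounds spoke only to ethyl and isopropyl.

The compounds shown leave open how far the true value of compound 4 lies past its limit, and whether the chain length or the double bond governs the result, which a saturated heptyl chain on the same core would separate. They also leave open how this position responds to an amine or a carboxylic acid at the end of such a chain.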